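Compound 4: A Methoxyphenyl Variant Awaits Measurement

This account rests on a few compounds, and the source may have more. Where it says the series, first, only, none or still open, it means among the compounds named here.

Compound 1 `CCCCCCCCn1cc(/C=C/C(=O)c2ccc(NC(=O)CN3CCN(c4ccccc4)CC3)cc2)nn1`, compound 2 `CCCCCCCCn1cc(/C=C/C(=O)c2ccc(NC(=O)CN3CCN(c4ccccc4F)CC3)cc2)nn1` and compound 3 `CCCCCCCCn1cc(/C=C/C(=O)c2ccc(NC(=O)CN3CCN(c4ccc([N+](=O)[O-])cc4)CC3)cc2)nn1` share one core and differ only in the aryl group attached to the ring nitrogen. In a functional assay on SK-N-SH cells (Homo sapiens) for inhibition, read by MTT assay (on this read-out lower numbers stand for stronger inhibition and higher numbers for weaker inhibition), compound 1 gives 41400 nM, compound 2 gives 60300 nM and compound 3 gives 51400 nM, the second highest of the three numbers. The steps of a 1.5-fold higher number from compound 1 to compound 2 (0.16 log units; within the scatter), a 1.2-fold higher number from compound 1 to compound 3 (0.09 log units; within the scatter) and a 1.2-fold lower number from compound 2 to compound 3 (0.07 log units; within the scatter) all stay within the scatter. Compound 4 `CCCCCCCCn1cc(/C=C/C(=O)c2ccc(NC(=O)CN3CCN(c4ccccc4OC)CC3)cc2)nn1` carries 2-methoxyphenyl in place of 4-nitrophenyl on an amine nitrogen in a ring. The two earlier aryl exchanges bear on this change, and since neither moved the number beyond the scatter, no step beyond it is expected here either. Compound 4 is therefore estimated at 50000 nM, between 25000 nM and 100000 nM, which would mean an expected step of a 1.0-fold lower number from compound 3 to compound 4 (0.01 log units; within the scatter).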

Compound 4, half-maximal inhibitory concentration: 21500 nM
The estimate for compound 4 lay 2.3-fold (0.37 log units) above the measured number; the whole stated range lies above it.
By their numbers in this assay, from the lowest: compounds 4, 1, 3 and 2 (each within the scatter of the next, the first and the last beyond it).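

In this assay, among these compounds, the aryl group on the amine nitrogen in a ring can move the number beyond the scatter: 2-methoxyphenyl brings a 2.4-fold lower number from compound 3 to compound 4 (0.38 log units; beyond the scatter) and a 2.8-fold lower number from compound 2 to compound 4 (0.45 log units; beyond the scatter), the first steps at this position to pass it. Yet a 1.9-fold lower number from compound 1 to compound 4 (0.28 log units; within the scatter) stays within the scatter, so methoxy stands apart from fluoro and 4-nitrophenyl here, but not from hydrogen. Nothing available here accounts for this difference. The compounds shown leave open whether an ethoxy group or an amine in place of the methoxy would read the same.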